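The source may hold more compounds than are shown below. What is called first, only, known or untested is meant among the compounds shown, and "the series" means these compounds.

Two compounds share one core and differ only in the group attached to an oxygen on a saturated carbon. Compound 1 `CC/N=C(\S)OC[C@H]1OC(n2cnc3c(NC4CCOC4)ncnc32)[C@H](O)[C@@H]1O` gives 33 nM in an assay on DDT1 cells (Cricetulus griseus) for binding affinity to adenosine receptor A1 (Homo sapiens), read by radioligand binding; on this read-out lower numbers stand for stronger inhibition and higher numbers for weaker inhibition. Compound 2 `O=C(NC1CC1)OC[C@H]1OC(n2cnc3c(NC4CCOC4)ncnc32)[C@H](O)[C@@H]1O`, which carries a cyclopropylcarbamoyl group there, gives 209 nM and so has the highest of the two numbers measured; its nearest neighbour is compound 1, with a 6.3-fold higher number from compound 1 to compound 2 (0.80 log units; beyond the scatter). Compound 3 `O[C@@H]1[C@@H](CO/C(S)=N/C2CCCCC2)OC(n2cnc3c(NC4CCOC4)ncnc32)[C@@H]1O` has not been measured. It differs from compound 2 by a group of 9 heavy atoms (7 carbon, 1 nitrogen, 1 sulfur; one six-membered non-aromatic ring of carbon only) in place of a group of 6 heavy atoms (4 carbon, 1 nitrogen, 1 oxygen; one three-membered non-aromatic ring of carbon only), on an oxygen on a saturated carbon. For the measured compounds named here, the entering group is of the same sulfur-containing type that compound 1 carries, so the only measured step that bears on this change is the one from compound 1 to compound 2, which raised the number. Reversing that kind of change is expected to lower the number by a similar amount, so compound 3 is estimated at 45 nM, between 12 nM and 170 nM, meaning an expected step of a 4.6-fold lower number from compound 2 to compound 3 (0.67 log units; beyond the scatter).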

Compound 3, inhibition constant: 253 nM
The estimate for compound 3 lay 5.6-fold (0.75 log units) below the measured number; measured number outside the range, above it.
By their numbers in this assay, from the lowest: compound 1; then compounds 2 and 3 (each within the scatter of the next).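

In this assay, replacing cyclopropylcarbamoyl with the sulfur-containing group that carries a cyclohexyl ring gives (a 1.2-fold higher number from compound 2 to compound 3 (0.08 log units; within the scatter)), so this pair cannot be told apart, and having the sulfur-containing type of group on this oxygen does not by itself give the low number of compound 1. Within that type, the group on the double-bonded nitrogen matters, since cyclohexyl in place of ethyl gives (a 7.7-fold higher number from compound 1 to compound 3 (0.88 log units; beyond the scatter)). No measurement shown here explains this loss.

The compounds shown leave open how the number changes for chains and rings of other sizes on that nitrogen, such as methyl, propyl or cyclopentyl. They also leave open whether an ethylcarbamoyl group would match compound 1 or compound 2, which would separate the effect of the ethyl group from that of the sulfur-containing type.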